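Bromo for Chloro on a Fused Bicyclic Core

The source may hold more compounds than are shown below. What is called first, only, known or untested is meant among the compounds shown, and "the series" means these compounds.

Compound 2 `CCOC(=O)Cn1cnc2ncnc(Cl)c21` gives 49800 nM in a functional assay on MCF7 cells (Homo sapiens) for antiproliferative activity, read by colorimetric assay and sulforhodamine B assay, with a stated time of 3 days (a lower number here means a stronger inhibitor, a higher number a weaker inhibitor), the highest of the two numbers measured; compound 1 `CCOC(=O)Cn1cnc2nc(Cl)nc(Cl)c21` gives 5630 nM in this assay, and an 8.8-fold higher number from compound 1 to compound 2 (0.95 log units; beyond the scatter). Compound 3 `CCOC(=O)Cn1cnc2ncnc(Br)c21` differs from compound 2 by bromo in place of chloro on an aromatic carbon. Among the measured compounds shown here, the only measured step concerns a chloro removed altogether, not exchanged for another halogen, so it bears only loosely on this change. With no halogen swap measured, no step beyond the scatter is expected in this assay for compound 3. Compound 3 is therefore expected to give 40000 nM (range 15000 nM to 130000 nM), an estimated step of a 1.2-fold lower number from compound 2 to compound 3 (0.10 log units; within the scatter).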

Compound 3, half-maximal inhibitory concentration: 20200 nM
For compound 3 the middle estimate is 2.0-fold (0.30 log units) above the measured one; the measured number falls inside the stated range.
By their numbers in this assay, from the lowest: compound 1; then compound 3; then compound 2.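

In this assay, the exchange of chloro for bromo at this position gives a 2.5-fold lower number from compound 2 to compound 3 (0.39 log units; beyond the scatter). The earlier step showed only the loss of a chloro from a different place on the shared core; this one shows that the number also responds when one halogen replaces another on this aromatic carbon. No measurement shown here explains the change. From the compounds shown here alone, whether an amine, a methoxy group or iodo at this position would lower the number further stays open. So does whether bromo would act the same way on the core of compound 1, which carries the second chloro.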